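The compounds below may be only part of what the source reports. "The series", "measured", "known", "first", "only" and "open" are said of these compounds alone.

Measured compounds in a functional assay on MCF7 cells (Homo sapiens) for cytotoxicity, read by MTT assay, with a stated time of 72 h; a lower number here means a stronger inhibitor, a higher number a weaker inhibitor:
- compound 1 `Nc1ccc(Nc2c(C(=O)NCc3ccc(F)cc3)nc(Br)c3cccnc23)cc1` gives 4000 nM
- compound 2 `N[C@H]1CC[C@H](Nc2c(C(=O)NCc3ccccn3)nc(Br)c3cccnc23)CC1` gives 15000 nM
- compound 3 `N[C@H]1CC[C@H](Nc2c(C(=O)NCc3ccc(F)cc3)nc(Br)c3cccnc23)CC1` gives 2000 nM

Compound 3 holds the lowest of the three numbers. One step is a 2.0-fold lower number from compound 1 to compound 3 (0.30 log units; within the scatter), within the scatter, so the two cannot be ordered; the other is a 7.5-fold lower number from compound 2 to compound 3 (0.88 log units; beyond the scatter), beyond the scatter.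

Compound 4 `NCCCCCCNc1c(C(=O)NCc2ccc(F)cc2)nc(Br)c2cccnc12` differs from compound 3 only on the nitrogen on the aromatic ring: 6-aminohexyl in place of 4-aminocyclohexyl on a nitrogen on an aromatic ring.

Among the compounds with values here, the one measured step that bears on this position, a 2.0-fold lower number from compound 1 to compound 3 (0.30 log units; within the scatter), swapped one amine-bearing ring for another without moving beyond the scatter. An open chain has not been tried here, so the expectation for compound 4 is a step of about a 1.5-fold higher number from compound 3 to compound 4 (0.18 log units; within the scatter), likely within the scatter, with a slight lean toward a higher number in this assay.

Compound 4 is therefore estimated at 3000 nM, in the range 1200 nM to 8000 nM.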

Compound 4, half-maximal inhibitory concentration: 2000 nM
Compound 4: the middle estimate sits 1.5-fold (0.18 log units) above what was measured; low and high end bracket the measured number.
By their numbers in this assay, from the lowest: compounds 3, 4 and 1 (each within the scatter of the next); then compound 2.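

In this assay the ring on the nitrogen on an aromatic ring is not needed to hold the number: the open 6-aminohexyl chain gives no change at the digits printed from compound 3 to compound 4 (within the scatter) and also a 2.0-fold lower number from compound 1 to compound 4 (0.30 log units; within the scatter). The two defined stereocentres of 4-aminocyclohexyl therefore carry no readable weight in this cytotoxicity read-out. Nothing at hand gives a reason for this. Still open, as far as these compounds go, is whether the terminal amine matters at all: a hydroxyl or a carboxylic acid at the chain end, or a shorter chain such as 3-aminopropyl, would separate the amine from chain length.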